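A few compounds are considered here, and "the series" means these few. Any claim that something is new, unique, unknown or untested is made for them only; others in the source may bear on it.

In a functional assay on MDA-MB-231 cells (Homo sapiens) for antiproliferative activity, read by MTT assay, with a stated time of 72 h (on this read-out lower numbers stand for stronger inhibition and higher numbers for weaker inhibition), compound 1 `COc1cc(-c2nccn2C(C)C)cc(OC)c1OC` gives > 100000 nM, which is a limit of the assay and not a number. Compound 2 `COc1cc(-c2nccn2S(=O)(=O)c2ccc(C)cc2)cc(OC)c1OC` gives > 100000 nM, also a limit. The two compounds therefore offer no measured number to compare, and the whole record so far is the limit of > 100000 nM in this assay, at which 2 of the 2 values shown sit. Compound 1 thus stands at that limit, with no measured value to fix its true position.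

The next compound, compound 3 `COc1cc(-c2nccn2-c2ccc(C)cc2)cc(OC)c1OC`, keeps the core of compound 1 and changes one group: 4-methylphenyl in place of isopropyl on an aromatic nitrogen. In words, 4-methylphenyl takes the place of isopropyl on an aromatic nitrogen. Within the data shown here, no measured step between related compounds is available to size this change. Compound 2 stays at > 100000 nM, so only a modest gain is expected in this assay, and no gain at all would not be a surprise. The expected change, an at least 2.5-fold lower number from compound 1 to compound 3 (0.39 log units; beyond the scatter), is an estimate that points towards stronger inhibition. For compound 3 the estimated value is 40000 nM, with an expected range from 8000 nM to 100000 nM.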

Compound 3, half-maximal inhibitory concentration: 4100 nM
Beside the measured number, compound 3's estimate is 9.8-fold (0.99 log units) above it, and the stated range ends above it.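

With the 4-methylphenyl group on the aromatic nitrogen, the series gains its first measured number in this assay, and the change from isopropyl is large: an at least 24-fold lower number from compound 1 to compound 3 (1.38 log units; beyond the scatter). This shows that the group on this nitrogen, two ring bonds from the other ring nitrogen, can decide whether the shared core stays at the limit of the assay or gives a measurable inhibition. The 4-methylphenyl group alone does not ensure this, since compound 2, which carries it through a sulfonyl group, gives > 100000 nM, a limit of the assay and not a number.

With a single measured number, no trend can be drawn across this position, and the rest of the record remains a limit: the limit of > 100000 nM in this assay, at which 2 of the 3 values shown sit. From the compounds shown here alone, it remains open whether the methyl group of the 4-methylphenyl plays any part, and whether an unsubstituted phenyl, a benzyl group, or a phenyl ring bearing a methoxy group, a chlorine atom or an amine on this nitrogen would give a lower or a higher number than compound 3.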